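Shortening the sulfur substituent in a selenium-containing series

The source may report more compounds than this note shows. Statements on the series, on what has been measured and on what is new or still open speak of the compounds shown alone.

Compound 1 `CCCCSc1n[nH]c(-n2[se]c3ccccc3c2=O)n1` in a functional assay on HeLa cells (Homo sapiens) for antiproliferative activity, read by CCK-8 assay, with a stated time of 48 h (a higher number here means a weaker inhibitor, a lower number a stronger inhibitor), gives 32900 nM.
Compound 2 `Cc1cccc(CSc2n[nH]c(-n3[se]c4ccccc4c3=O)n2)c1` in this assay gives 42600 nM.

Among the two measured compounds, compound 2 carries the higher of the two numbers, but its only neighbour is compound 1, and the gap is small: a 1.3-fold higher number from compound 1 to compound 2 (0.11 log units; within the scatter). The two values therefore cannot be told apart.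

Compound 3 `CCCSc1n[nH]c(-n2[se]c3ccccc3c2=O)n1` differs from compound 2 by ethyl in place of 3-methylphenyl on a saturated chain carbon bound to a sulfur. Going by the values given here, the only measured step that bears on this change is the one from compound 1 to compound 2, where a propyl was exchanged for a 3-methylphenyl at the same place and the number barely moved. The change to compound 3 runs the other way and trims the chain one carbon shorter than in compound 1. Nothing in the measured pair suggests that this part of the molecule shifts the number beyond the scatter, so compound 3 is expected to land close to compound 2, with a 1.1-fold lower number from compound 2 to compound 3 (0.05 log units; within the scatter). The estimate for compound 3 is 38000 nM, with a range from 15000 nM to 95000 nM.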

Compound 3, half-maximal inhibitory concentration: 30400 nM
For compound 3 the middle estimate is 1.3-fold (0.10 log units) above the measured one, within the range that was stated.
By their numbers in this assay, from the lowest: compounds 3, 1 and 2 (each within the scatter of the next).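

Exchanging the 3-methylphenyl for ethyl removes a whole aromatic ring at this place, on a saturated chain carbon bound to a sulfur, and this assay still shows only a 1.4-fold lower number from compound 2 to compound 3 (0.15 log units; within the scatter), a change too small to read as a real difference. Trimming the chain by one carbon, with hydrogen in place of methyl on a saturated chain carbon, three bonds along the chain from a sulfur, gives a 1.1-fold lower number from compound 1 to compound 3 (0.03 log units; within the scatter), so this change cannot be told apart from no change at all. Together with the earlier step, this means that among these three compounds neither removing the ring nor shortening the chain separates the numbers, and nothing available accounts for that flat result.

As far as these compounds go, all three groups compared here are built from carbon and hydrogen alone, so it remains open whether an amine, a carboxylic acid or a much longer chain on the sulfur would move the number beyond the scatter. The compounds shown also leave open how much changes to the shared core, such as a fluorine on its benzene ring, would matter compared with changes on the sulfur.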